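A few compounds are considered here, and "the series" means these few. Any claim that something is new, unique, unknown or untested is made for them only; others in the source may bear on it.

Compound 1 `N#Cc1c(Nc2ccccc2Cl)nc(SCc2cn(Cc3ccccc3Cl)nn2)nc1-c1ccccc1` gives 28500 nM in a functional assay on ECa-109 cells (Homo sapiens) for inhibition, read by MTT assay, with a stated time of 72 h (a lower number here means a stronger inhibitor, a higher number a weaker inhibitor), and stands level with compound 3 `N#Cc1c(Nc2ccc(F)cc2)nc(SCc2cn(Cc3ccccc3Cl)nn2)nc1-c1ccccc1`, which gives 25800 nM, the step being a 1.1-fold lower number from compound 1 to compound 3 (0.04 log units; within the scatter). Compound 2 `N#Cc1c(Nc2cccc([N+](=O)[O-])c2)nc(SCc2cn(Cc3ccccc3Cl)nn2)nc1-c1ccccc1` gives > 64000 nM, a limit of this assay and not a number. Compound 4 `Cc1ccc(Cn2cc(CSc3nc(Nc4ccccc4Cl)c(C#N)c(-c4ccccc4)n3)nn2)cc1` differs from compound 1 by 4-methylphenyl in place of 2-chlorophenyl on a saturated chain carbon bound to an aromatic nitrogen. The measured steps, an at least 2.2-fold higher number from compound 1 to compound 2 (0.35 log units; beyond the scatter) and an at least 2.4-fold lower number from compound 2 to compound 3 (0.39 log units; beyond the scatter), all exchange the aryl on a nitrogen on an aromatic ring and leave the 2-chlorobenzyl untouched, so none bears directly on the present change. Within the data shown here, with no measured step at this position, no shift beyond the scatter is expected, no change at the digits printed from compound 1 to compound 4 (within the scatter). Compound 4 is therefore estimated at 28500 nM, with a range from 12000 nM to 64000 nM.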

Compound 4, half-maximal inhibitory concentration: 11200 nM
Estimate against measurement, compound 4: 2.5-fold (0.41 log units) above; measured number below the stated range.
By their numbers in this assay, from the lowest: compound 4; then compounds 3 and 1 (each within the scatter of the next). At a limit, above all of these: compound 2.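

In this assay, the group on a saturated chain carbon bound to an aromatic nitrogen proves able to move the read-out: 4-methylphenyl in place of 2-chlorophenyl gives a 2.5-fold lower number from compound 1 to compound 4 (0.41 log units; beyond the scatter). This is the only step shown at this position, and both groups count the same heavy atoms, so a difference in size by that count does not describe it. Nothing shown accounts for the shift.

A 4-chlorophenyl or a 2-methylphenyl at this position would separate the identity of the substituent from its place on the ring. As far as these compounds go, whether an amine or a carboxylic acid on this ring keeps the lower number remains open, as does whether 4-methylphenyl has the same effect alongside the 4-fluorophenyl of compound 3.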